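This account rests on a few compounds, and the source may have more. Where it says the series, first, only, none or still open, it means among the compounds named here.

Among the measured compounds shown here, in an ADME assay on J774.A1 cells (Mus musculus) for cytotoxicity, read by MTT assay, with a stated time of 48 h (on this read-out lower numbers stand for higher toxicity in this test and higher numbers for lower toxicity in this test), only two compounds have numbers so far. Compound 1 `COc1cccc(CNC(=O)c2c([N+](=O)[O-])noc2-c2ccc(Cl)cc2)c1` gives 68600 nM, while compound 2 `COC(=O)c1c(NCCNc2ccnc3cc(Cl)ccc23)noc1-c1ccc([N+](=O)[O-])cc1` gives 3790 nM, the lower of the two numbers and so the higher toxicity in this test. These two compounds differ in more than one place, so their gap says little about any single group. Compound 3 `COC(=O)c1c(NCCNc2ccnc3cc(Cl)ccc23)noc1-c1ccccc1[N+](=O)[O-]` has the same atoms as compound 2, joined differently: 2-nitrophenyl in place of 4-nitrophenyl on an aromatic carbon, next to the ring oxygen (2-nitrophenyl in place of 4-nitrophenyl on an aromatic carbon). The rest of the molecule stays as it is. For the measured compounds named here, no measured pair shows what this kind of change does, so the expectation in this assay is a small step, with no favoured direction and probably none beyond the scatter. The estimated change is a 1.1-fold higher number from compound 2 to compound 3 (0.02 log units; within the scatter). For compound 3 the estimated value is 4000 nM, with an expected range of 1800 nM to 9000 nM.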

Compound 3, half-maximal cytotoxic concentration: 73600 nM
Estimate against measurement, compound 3: 18-fold (1.26 log units) below; measured number above the stated range.
By their numbers in this assay, from the lowest: compound 2; then compounds 1 and 3 (each within the scatter of the next).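

In this assay, swapping 4-nitrophenyl for 2-nitrophenyl gives a 19-fold higher number from compound 2 to compound 3 (1.29 log units; beyond the scatter), and this higher number stands for lower toxicity in this test. Among the compounds shown here, this is the first single change seen here, and it shows that the arrangement of the group on this aromatic carbon, next to the ring oxygen, can shift the result well beyond the scatter even though no atom is gained or lost. No measurement at hand explains why the two arrangements differ.

From the compounds shown here alone, this rests on one pair on one core, so it stays open whether the same swap would act alike on another core. Going by these compounds, it is also open whether the nitro group is needed at all, which a plain phenyl ring or a phenyl carrying an amine or a carboxylic acid could test.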